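This account rests on a few compounds, and the source may have more. Where it says the series, first, only, none or still open, it means among the compounds named here.

Three compounds of one series have been examined in a toxicity assay on MDCK cells (Canis lupus familiaris) for cytotoxicity, read by crystal violet staining, with a stated time of 48 h (on this read-out higher numbers stand for lower toxicity in this test and lower numbers for higher toxicity in this test), and all three gave only limits. Compound 1 `Cc1ccc2cc(CN(Cc3ccc(F)cc3)Cc3ccc(C(C)C)cc3)c(=O)[nH]c2c1` carries a 4-isopropylbenzyl group on a shared core. In this assay compound 1 reached the limit > 33000 nM, which is a limit of the measurement and not a number. Compound 2 `Cc1ccc2cc(CN(Cc3ccc(F)cc3)Cc3ccc(C(C)(C)C)cc3)c(=O)[nH]c2c1` differs from compound 1 by methyl in place of hydrogen on a saturated chain carbon bound to an aromatic carbon and two saturated chain carbons. In this assay compound 2 likewise stopped at the limit > 33000 nM, again a limit rather than a number. The resulting step that the two limits leave unreadable from compound 1 to compound 2 is one that the two limits leave unreadable, as the limit of > 33000 nM in this assay, at which 2 of the 3 values shown sit, shows. Compound 3 `CCCOc1ccc(CN(Cc2ccc(C(C)(C)C)cc2)Cc2cc3cc(C)ccc3[nH]c2=O)cc1` has a different core; the difference between the two cores is not broken down here. In this assay compound 3 gave the limit > 5000 nM, which is a limit, as the limit of > 5000 nM in this assay, at which 1 of the 3 values shown sits, records.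

Compound 4 `CCCCOc1ccc(CN(Cc2ccc(C(C)(C)C)cc2)Cc2cc3cc(C)ccc3[nH]c2=O)cc1` is not yet measured. It differs from compound 3 by methyl in place of hydrogen on a saturated chain carbon, three bonds along the chain from an oxygen on an aromatic ring. This is the same kind of change as that from compound 1 to compound 2, but at another place: there the methyl enters on a saturated chain carbon bound to an aromatic carbon and two saturated chain carbons, here on a saturated chain carbon three bonds along the chain from an oxygen on an aromatic ring. Since the step from compound 1 to compound 2 is unreadable and all three values are limits, the step that the limit leaves unreadable from compound 3 to compound 4 is expected to be small. Compound 4 is therefore estimated at 30000 nM, within 5000 nM to 100000 nM in this assay, most likely again reported only as a limit.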

Compound 4, half-maximal cytotoxic concentration: > 5000 nM
Compound 4: only a limit was reported; the forecaster's own chance of this, stated with the estimate: 75%; the middle value does not contradict the limit.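

In this assay compound 4 gave > 5000 nM, which is a limit and not a number. Compound 3 also gave only a limit, so no step between compound 3 and compound 4 can be read: the limit of > 5000 nM in this assay, at which 2 of the 4 values shown sit.

What stays open is whether propyl to butyl, or any other change shown, alters the half-maximal cytotoxic concentration at all, as none of the four compounds has given a number.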